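The source may hold more compounds than are shown below. What is called first, only, known or untested is meant among the compounds shown, and "the series" means these compounds.

Compound 1 `C#CCn1cc(C(=O)NC(CC(=O)Nc2ccccc2)c2ccccc2)c(=O)c2cc(F)c(Cl)nc21`: > 10000 nM
Compound 2 `C#CCn1cc(C(=O)NC(CC(=O)Nc2ccccc2)c2ccccc2)c(=O)c2ccc(Cl)nc21`: > 10000 nM

In a functional assay on KB cells (Homo sapiens) for cytotoxicity, read by MTT assay, with a stated time of 72 h (on this read-out lower numbers stand for stronger inhibition and higher numbers for weaker inhibition), compound 1 gives > 10000 nM, which is a limit of the assay rather than a number. Compound 2 gives > 10000 nM, also a limit. The step that the two limits leave unreadable from compound 1 to compound 2 is therefore unreadable. Compound 1 stands at that limit, since (the limit of > 10000 nM in this assay, at which 2 of the 2 values shown sit).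

Compound 3 `C#CCn1cc(C(=O)NC(CC(=O)Nc2ccccn2)c2ccccc2)c(=O)c2cc(F)c(Cl)nc21` differs from compound 1 by pyridin-2-yl in place of phenyl on an amide-type nitrogen. Within the data shown here, no measured step bears on this change, and with compound 1 at a limit no shift beyond the scatter can be foreseen.

Compound 3 is expected to give 15000 nM, within 5000 nM to 50000 nM. Such a value would mean an expected step that the limit leaves unreadable from compound 1 to compound 3.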

Compound 3, half-maximal inhibitory concentration: 2300 nM
Compound 3: middle estimate off by 6.5-fold (0.81 log units), on the high side, and the stated range ends above it.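

In this assay, the group on the amide-type nitrogen proves able to move the read-out: pyridin-2-yl in place of phenyl gives an at least 4.3-fold lower number from compound 1 to compound 3 (0.63 log units; beyond the scatter). Compounds 1 and 2 could not show this, as neither gave a readable number. The step is only a minimum, and its full size remains unknown, because compound 1 stands at a limit: the limit of > 10000 nM in this assay, at which 2 of the 3 values shown sit.

From the compounds shown here alone, whether other rings on this nitrogen, such as pyridin-3-yl, would give a similar step remains open. So does the effect of a carboxylic acid or an amine on the ring.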